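This account rests on a few compounds, and the source may have more. Where it says the series, first, only, none or still open, it means among the compounds named here.

Compound 3 `CC(C)c1ccc(S(=O)(=O)NCCCCCCNCc2ccc(Br)cc2)cc1` was run in a functional assay on MIA PaCa-2 cells (Homo sapiens) for inhibition, read by MTT assay, with a stated time of 72 h (a higher number here means a weaker inhibitor of growth, a lower number a stronger inhibitor of growth), where compound 3 gives 5730 nM. Among the three measured compounds it stands second highest: compound 2 `CC(C)(C)c1ccc(CNCCCNS(=O)(=O)c2cc(C(F)(F)F)cc(C(F)(F)F)c2)cc1` gives 2300 nM in this assay, and compound 1 `CC(C)(C)c1ccc(CNCCNS(=O)(=O)c2cc(C(F)(F)F)cc(C(F)(F)F)c2)cc1` gives 15000 nM, so compound 3 sits between them, with a higher number than compound 2 and a lower one than compound 1. Compound 4 `O=[N+]([O-])c1ccc(S(=O)(=O)NCCCCCCNCc2ccc(Br)cc2)cc1` differs from compound 3 in a single place (nitro in place of isopropyl on an aromatic carbon). Going by the values given here, no measured pair shows this change, so the size of its step has no precedent here. A small step in this assay is expected, more likely toward a higher number, though possibly none beyond the scatter, a 1.2-fold higher number from compound 3 to compound 4 (0.09 log units; within the scatter). Compound 4 is therefore estimated at 7000 nM, within 2500 nM to 20000 nM.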

Compound 4, concentration for 50% growth inhibition: 9800 nM
Compound 4: the middle estimate sits 1.4-fold (0.15 log units) below what was measured; the measured number falls inside the stated range.
By their numbers in this assay, from the lowest: compound 2; then compounds 3, 4 and 1 (each within the scatter of the next, the first and the last beyond it).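

In this assay, the change from 4-isopropylphenyl to 4-nitrophenyl gives a 1.7-fold higher number from compound 3 to compound 4 (0.23 log units; within the scatter). Going by these compounds alone, on this aromatic carbon, para to a large group, nitro therefore takes the place of isopropyl with no shift beyond the scatter, something the earlier compounds, which offered no single-place pair, could not show. Nothing available bears on why the step has this size. From the compounds shown here alone, whether an amine or a carboxylic acid on this carbon would also leave the number within the scatter stays open. So does the effect of a shorter chain in the shared core.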